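From 4-nitrophenyl to 4-methylphenyl, close to an assay limit

This account rests on a few compounds, and the source may have more. Where it says the series, first, only, none or still open, it means among the compounds named here.

Compound 1 `O=C1NC(=O)/C(=C/c2cn(Cc3ccc([N+](=O)[O-])cc3)c3ccccc23)N1` gives > 40000 nM in a functional assay on NCI-H460 cells (Homo sapiens) for antiproliferative activity, read by trypan blue exclusion, with a stated time of 24 h (a higher number here means a weaker inhibitor, a lower number a stronger inhibitor), and this is a limit of the assay, not a number. Compound 2 `O=C1NC(=O)/C(=C/c2cn(Cc3ccccc3)c3ccc(Cl)cc23)N1` gives 26900 nM in this assay. Compound 3 `O=C1NC(=O)/C(=C/c2cn(Cc3ccccc3)c3ccc(Br)cc23)N1` gives > 40000 nM, which is again a limit.

Compound 4 `Cc1ccc(Cn2cc(/C=C3\NC(=O)NC3=O)c3ccccc32)cc1` keeps the core of compound 1 and differs from it in one group: methyl in place of nitro on an aromatic carbon. For the measured compounds named here, the only measured step is an at least 1.4-fold higher number from compound 2 to compound 3 (0.17 log units; that floor lies within the scatter), with bromo in place of chloro on an aromatic carbon, and its floor lies within the scatter. Going by the values given here, that step involves neither nitro nor methyl, so it offers only weak guidance, and no measured step covers this exchange directly. No step beyond the scatter is therefore expected in this assay, and the direction remains uncertain. The expectation stays high because of the limit of > 40000 nM in this assay, at which 2 of the 3 values shown sit.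

The expected change is an at least 1.2-fold lower number from compound 1 to compound 4 (0.09 log units; that floor lies within the scatter). The estimate for compound 4 is 32000 nM, with an expected range from 14000 nM to 70000 nM.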

Compound 4, half-maximal inhibitory concentration: 26100 nM
Compound 4: the middle estimate sits 1.2-fold (0.09 log units) above what was measured, and the stated range covers the measured number.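

Placing methyl instead of nitro on the aromatic carbon para to a large group gives an at least 1.5-fold lower number from compound 1 to compound 4 (0.18 log units; that floor lies within the scatter), the first step shown at this position. Compound 4 gives 26100 nM in this assay, a measured number, so with methyl at this place the result can be read within the range of the assay, although the step remains within the scatter. The true size of the step stays unknown because compound 1 gives only a limit of the assay, not a number: the limit of > 40000 nM in this assay, at which 2 of the 4 values shown sit.

The compounds shown leave open whether a methoxy group, an amine or a carboxylic acid at this place would move the number beyond the scatter. They also leave open how methyl at this place would read together with the chloro of compound 2 or the bromo of compound 3.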